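This account rests on a few compounds, and the source may have more. Where it says the series, first, only, none or still open, it means among the compounds named here.

Compound 1 `C[Se]c1nc(N)c2ccccc2n1`: 65100 nM
Compound 2 `COc1ccc(CNc2nc([SeH])nc3ccccc23)cc1`: > 100000 nM, a limit
Compound 3 `Nc1nc([SeH])nc2ncccc12`: 30900 nM

In a functional assay on CCRF-CEM cells (Homo sapiens) for cytotoxicity, read by MTT assay, with a stated time of 72 h (on this read-out higher numbers stand for weaker inhibition of growth and lower numbers for stronger inhibition of growth), compound 1 gives 65100 nM, the higher of the two numbers; compound 3 gives 30900 nM, lower by a margin beyond the usual scatter. Compound 2 sits at the limit of > 100000 nM in this assay, at which 1 of the 3 values shown sits, which is a limit of the assay and not a number.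

Compound 4 `Nc1nc([SeH])nc2ccccc12` has not been measured. It differs from compound 1 by hydrogen in place of methyl on a selenium. Within the data shown here, no measured pair shows this change alone, and compound 3 differs from compound 1 in the ring as well, so no direct step can be read. The expected step is a 1.6-fold lower number from compound 1 to compound 4 (0.21 log units; within the scatter), a small move toward a lower number that may not exceed the scatter. Compound 4 is estimated at 40000 nM, between 12000 nM and 130000 nM.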

Compound 4, concentration for 50% growth inhibition: 25700 nM
The estimate for compound 4 lay 1.6-fold (0.19 log units) above the measured number, and the stated range covers the measured number.
By their numbers in this assay, from the lowest: compounds 4 and 3 (each within the scatter of the next); then compound 1. At a limit, above all of these: compound 2.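

In this assay, among these compounds, the group on this selenium matters: hydrogen in place of methyl gives a 2.5-fold lower number from compound 1 to compound 4 (0.40 log units; beyond the scatter) and is the only single change that can be read in this set. In this one pair, then, the methyl on selenium goes with weaker inhibition of growth. Nothing measured here explains the step.

With only hydrogen and methyl shown at this selenium, it remains open whether an ethyl group, a longer chain or a benzyl group would keep this direction. Going by these compounds, whether the same step holds on another core also remains open.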